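Swapping an Amino Group for a Longer Chain

This account rests on a few compounds, and the source may have more. Where it says the series, first, only, none or still open, it means among the compounds named here.

Compound 1 `Nc1nc(-c2ccccc2)nn1-c1ncnc2cc(Cl)ccc12`: 300 nM
Compound 2 `COc1cc2ncnc(-n3nc(-c4ccccn4)nc3N)c2cc1N`: 3000 nM
Compound 3 `COc1cc2ncnc(-n3cnc(-c4ccccn4)n3)c2cc1OC`: 30000 nM

In a physicochemical assay for solubility, in phosphate buffer, with a stated time of 18 h, at pH 7.4 (a lower number here means a less soluble compound, a higher number a more soluble compound), compound 2 gives 3000 nM, the middle of the three numbers. Compound 1 lies lower and compound 3 higher, each beyond the usual scatter. Compound 4 `COc1cc2ncnc(-n3nc(-c4ccccn4)nc3N)c2cc1OCCNC(=O)OC(C)(C)C` has not yet been measured. It differs from compound 2 in one place: 2-((tert-butoxycarbonyl)amino)ethoxy in place of amino on an aromatic carbon. Here 2-((tert-butoxycarbonyl)amino)ethoxy stands in place of amino on an aromatic carbon, ortho to a methoxy group. For the measured compounds named here, no two measured compounds differ in only one place, so the data offer no direct guide and the expectation stays broad. A fall is expected, and the estimated step is a 3.0-fold lower number from compound 2 to compound 4 (0.48 log units; beyond the scatter). Compound 4 is estimated at 1000 nM, with an expected range of 150 nM to 5000 nM.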

Compound 4, solubility: 2000 nM
The estimate for compound 4 lay 2.0-fold (0.30 log units) below the measured number; the range from low to high includes it.
By their numbers in this assay, from the lowest: compound 1; then compounds 4 and 2 (each within the scatter of the next); then compound 3.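

In this assay this aromatic carbon, ortho to a methoxy group, gives the first direct comparison: 2-((tert-butoxycarbonyl)amino)ethoxy in place of amino gives a 1.5-fold lower number from compound 2 to compound 4 (0.18 log units; within the scatter) and so the two compounds cannot be told apart, even though the entering group has 11 heavy atoms and the leaving group has 1. No measurement shown here gives a reason for this result. Still open, from the compounds shown here alone, is whether a free aminoethoxy chain, a carboxylic acid or a longer chain on this carbon would also stay within the scatter of compound 2. One pair also cannot show whether the same holds on a different core.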